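The compounds below may be only part of what the source reports. "The series", "measured", "known", "first", "only" and "open" are said of these compounds alone.

Compound 3, `N#Cc1ccc(Cn2c(=O)n(C3OC(CO)[C@@H](O)[C@H]3O)c3nc(N)nc(O)c32)cc1`, is a member of a small set of three purine-like analogues measured in a functional assay on the whole organism (B cells) with Mus musculus as the target; on this read-out lower numbers stand for smaller maximal responses and higher numbers for larger maximal responses. In this assay compound 3 gives 50%, which places it second highest of the three numbers. For the measured compounds named here, compound 1, `CCOC(=O)Cn1c(=O)n(C2OC(CO)[C@@H](O)[C@H]2O)c2nc(N)nc(O)c21`, reaches 86%, and the single one-place step recorded among the measured compounds, a number 36 percentage points lower from compound 1 to compound 3 (beyond the scatter), is the replacement of ethoxycarbonyl by 4-cyanophenyl on a saturated chain carbon bound to an aromatic nitrogen. Going by the values given here, compound 2, `Cn1c(=O)n(C2OC(CI)[C@@H](O)[C@H]2O)c2nc(N)nc(O)c21`, gives 32%; it carries a methyl at that position but also an iodo in place of the hydroxyl on the sugar, so no single-place step links it to compound 3.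

Compound 4, `Cn1c(=O)n(C2OC(CO)[C@@H](O)[C@H]2O)c2nc(N)nc(O)c21`, differs from compound 3 only at this position: hydrogen in place of 4-cyanophenyl on a saturated chain carbon bound to an aromatic nitrogen. Among the compounds with values here, the one relevant step, from compound 1 to compound 3, shows that a large change at this carbon can move the response by a large amount, but in that case an ethoxycarbonyl was exchanged for 4-cyanophenyl, not for hydrogen. With compound 1 high and compound 2 low, the direction for a bare methyl is uncertain. A step of a number 5 percentage points higher from compound 3 to compound 4 (within the scatter) is therefore expected, within the scatter. Compound 4 is estimated at 55%, in the range 30% to 85%.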

Compound 4, largest response reached (reported as maximal response), in percent of the reference or control that the assay uses: 99%
Compound 4: the middle estimate sits 44 percentage points below what was measured, and the stated range ends below it.
By their numbers in this assay, from the lowest: compound 2; then compound 3; then compound 1; then compound 4.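

The result shows that hydrogen on this saturated chain carbon bound to an aromatic nitrogen, which reads as methyl when cut one bond further out, gives a larger maximal response than either larger group shown, and that the size of the gain depends on the group it replaces. In this assay, there is a number 49 percentage points higher from compound 3 to compound 4 (beyond the scatter) on losing 4-cyanophenyl, and the smaller a number 13 percentage points higher from compound 1 to compound 4 (beyond the scatter) on losing ethoxycarbonyl, so both groups go with a lower number, whereas the earlier step could only rank them against each other. The methyl is also no liability in itself: the low number of the methyl compound seen earlier goes with the iodo on the saturated chain carbon bound to a saturated ring carbon, as there is a number 67 percentage points higher from compound 2 to compound 4 (beyond the scatter) with hydroxy in place of iodo.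

The compounds shown leave open where a plain longer chain such as ethyl or propyl, an amine, or a carboxylic acid in place of ethoxycarbonyl would fall at this position, and whether a fluoro or an amine on the sugar chain carbon would behave like iodo or like hydroxy. Nothing given here accounts for the size of these steps.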